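The source may hold more compounds than are shown below. What is called first, only, known or untested is meant among the compounds shown, and "the series" means these compounds.

Working notes on the series. Among the compounds with values here, in a functional assay on FM3A cells (Mus musculus) for antiproliferative activity, with a stated time of 48 h (on this read-out higher numbers stand for weaker inhibition and lower numbers for stronger inhibition), compound 3 `Nc1ccc(/C=C/C(=O)c2ccccc2)cc1` gives 146000 nM, the highest of the three numbers so far and so the weakest inhibition measured. Compound 1 `C=C(Br)C(=O)Nc1ccc(/C=C/C(=O)c2ccccc2)cc1` gives 3900 nM, and compound 2 `C=C(Br)C(=O)Nc1ccc(C(=O)/C=C/c2ccc(OC)cc2)cc1` gives 1000 nM.

The next compound is compound 4 `Nc1ccc(/C=C/C(=O)c2ccc(Cl)cc2)cc1`, which keeps the free amine of compound 3 and carries chloro in place of hydrogen on an aromatic carbon, para to a large group: chloro in place of hydrogen on an aromatic carbon.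

Within the data shown here, only one measured step is available, a 37-fold higher number from compound 1 to compound 3 (1.57 log units; beyond the scatter), a large change beyond the scatter. That step concerns the (1-bromoethenyl)carbonyl group on the nitrogen, whereas the new change lies elsewhere and leaves the nitrogen untouched. Among the measured compounds shown here, its size therefore should not carry over, and no measured step shows what chloro does.

A small shift in this assay toward a lower number is expected, and it may not clear the scatter. For the measured compounds named here, the expected step is a 2.1-fold lower number from compound 3 to compound 4 (0.32 log units; beyond the scatter), well short of the size of the one measured step. For compound 4 the estimated value is 70000 nM, with an expected range of 20000 nM to 200000 nM.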

Compound 4, half-maximal inhibitory concentration: 178000 nM
Beside the measured number, compound 4's estimate is 2.5-fold (0.41 log units) below it; low and high end bracket the measured number.
By their numbers in this assay, from the lowest: compound 2; then compound 1; then compounds 3 and 4 (each within the scatter of the next).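

In this assay chloro in place of hydrogen on an aromatic carbon, para to a large group, gives a 1.2-fold higher number from compound 3 to compound 4 (0.09 log units; within the scatter) and the two numbers stand within the scatter of each other. Within the data shown here, this is the first measured step on this ring, and with the free amine on the nitrogen it shows no measurable effect of chloro, whereas the one step at the nitrogen, a 37-fold higher number from compound 1 to compound 3 (1.57 log units; beyond the scatter) lies well beyond the scatter. Nothing available accounts for this result.

Both free amines sit at the weak end of the measured range, so the result says nothing about whether chloro would have an effect in a compound carrying the (1-bromoethenyl)carbonyl group on the nitrogen, where the numbers are far lower. Going by these compounds, it also remains open whether a different group on the same aromatic carbon, such as a nitrile, a carboxylic acid or a dimethylamino group, would move the number beyond the scatter where chloro does not.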